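Aminothiazole naphthyl ethers: cytotoxicity notes before the bromo swap

The compounds below may be only part of what the source reports. "The series", "measured", "known", "first", "only" and "open" are said of these compounds alone.

compound 1 `COCCNc1ncc(C(Oc2ccc3cc(Br)ccc3c2)c2ccc(Cl)cc2)s1` — "not toxic" (no number reported)
compound 2 `CCCCCC(=O)Nc1ncc(C(Oc2ccc3cc(Br)ccc3c2)c2ccc(Cl)cc2)s1` — > 50000 nM
compound 3 `O=C(Nc1ncc(C(Oc2ccc3cc(Br)ccc3c2)c2ccc(Cl)cc2)s1)c1ccc(F)cc1F` — "not toxic" (no number reported)

In an ADME assay on HepG2 2.2.15 cells (Homo sapiens) for cytotoxicity (on this read-out lower numbers stand for higher toxicity in this test and higher numbers for lower toxicity in this test), compound 3 gives "not toxic" (no number reported), a reading without a single number. Compound 2 gives > 50000 nM, which is a limit of the assay; (the limit of > 50000 nM in this assay, at which 1 of the 3 values shown sits). Compound 1 likewise gives "not toxic" (no number reported) with no number reported. Going by the values given here, no step between measured compounds is available, so compound 3 can only be placed among readings that all sit at or past the limit.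

Compound 4 `O=C(Nc1ncc(C(Oc2ccc3cc(Br)ccc3c2)c2ccc(Cl)cc2)s1)c1ccc(F)cc1Br` differs from compound 3 by bromo in place of fluoro on an aromatic carbon. With every reading in this assay at or past the limit, no shift beyond the usual scatter is expected from this change. Compound 4 is expected to give 60000 nM in this assay, within 20000 nM to 200000 nM, most likely reported again only as a limit.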

Compound 4, half-maximal cytotoxic concentration: > 50000 nM
Compound 4: no number, only a limit; the forecaster's own chance of this, stated with the estimate: 85%; the middle value lies beyond the limit too.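

In this assay compound 4 gives > 50000 nM, a limit and not a number. No new step can be read between compound 4 and compound 2 or compound 3. The compounds shown leave open at what concentration, if any, cytotoxicity would appear.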